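The source may hold more compounds than are shown below. What is called first, only, known or untested is meant among the compounds shown, and "the series" means these compounds.

Working notes on the succinimide-piperazine series.

Compound 1 `CCC(C(=O)N1CCN(c2ccccc2Cl)CC1)N1C(=O)CCC1=O` is the reference for the first core. In a functional assay on the whole organism (strain Swiss) with Mus musculus as the target, in the maximal electroshock model, with a stated time of 1 h, at a dose of 300 mg/kg by the intraperitoneal route (a lower number here means a weaker effect, a higher number a stronger effect of the compound at the dose given), compound 1 gives 50%. Compound 3 `CC(C(=O)N1CCN(c2ccccc2Cl)CC1)N1C(=O)CCC1=O` differs from it by one change (hydrogen in place of methyl on a saturated chain carbon, two bonds along the chain from an amide-type nitrogen in a ring and a carbonyl carbon). In this assay compound 3 gives 25%, so the change made a step of a number 25 percentage points lower from compound 1 to compound 3 (beyond the scatter).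

Compound 2 `CCC(C(=O)N1CCN(c2cccc(C(F)(F)F)c2)CC1)N1C(=O)CCC1=O` carries a second core; the difference between the two cores is not broken down here. In this assay compound 2 gives 100%, the highest number of the three measured and beyond the scatter from both compound 1 and compound 3.

Compound 4 `CC(C(=O)N1CCN(c2cccc(C(F)(F)F)c2)CC1)N1C(=O)CCC1=O` is not yet measured. It stands to compound 2 as compound 3 stands to compound 1, through the same change (hydrogen in place of methyl on a saturated chain carbon, two bonds along the chain from an amide-type nitrogen in a ring and a carbonyl carbon), the place being described in the same words for both pairs. For compound 4 a step of a number 25 percentage points lower from compound 2 to compound 4 (beyond the scatter) is expected, resting on the step seen from compound 1 to compound 3 because a number 25 percentage points lower from compound 1 to compound 3 (beyond the scatter), with the upper value of compound 2 leaving room only downward. The estimate for compound 4 is 75%, expected between 50% and 100%.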

Compound 4, a percentage reported as activity, at one dose (the size of the read-out at that dose, not a potency): 100%
The estimate for compound 4 lay 25 percentage points below the measured number; the measured number falls inside the stated range.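

On the second core, the change from ethyl to methyl gives no change at the digits printed from compound 2 to compound 4 (within the scatter) in this assay, so the loss seen on the first core does not carry over. Going by these compounds alone, the same change therefore gives a different result on the two cores: the same change on two cores in this assay, a number 25 percentage points lower (beyond the scatter) from compound 1 to compound 3 and no change at the digits printed (within the scatter) from compound 2 to compound 4, 25 percentage points apart, beyond the scatter of two such steps This rests on only two matched pairs at a single dose, with both compounds of the second pair at the top of the percentage scale; it does not show a rule for the series, which feature of the cores sets the difference, or whether the two compounds of the second pair would match at lower doses, as the read-out is not a potency.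

The compounds shown leave open whether a longer chain such as propyl would follow the same course on the two cores. Going by these compounds, it also remains open how the change from ethyl to methyl would behave on a core carrying a nitrile or an amine in place of the trifluoromethyl.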